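Series notes: cytotoxicity limits and one open compound

A few compounds are considered here, and "the series" means these few. Any claim that something is new, unique, unknown or untested is made for them only; others in the source may bear on it.

Compound 1 `Cc1ccc(-c2ccc3ncc(-c4noc(C(F)(F)F)n4)cc3c2)cc1` is the reference of the set. In a functional assay on RD cells (Homo sapiens) for inhibition, read by luminescence and ATP content, with a stated time of 72 h (on this read-out higher numbers stand for lower toxicity in this test and lower numbers for higher toxicity in this test), compound 1 gives only a limit, > 22200 nM. Compound 2 `FC(F)(F)c1nc(-c2cnc3ccc(-c4ccccc4)cc3c2)no1` carries hydrogen in place of methyl on an aromatic carbon. In this assay compound 2 likewise gives a limit, > 22200 nM. The step that the two limits leave unreadable from compound 1 to compound 2 is unreadable because both values sit at the limit of > 22200 nM in this assay, at which 2 of the 3 values shown sit. Compound 3 `CCc1nc(-c2cnc3ccc(-c4ccc(C)cc4)cc3c2)no1` differs from compound 1 by ethyl in place of trifluoromethyl on an aromatic carbon. In this assay compound 3 gives a limit, > 7400 nM. The step that the two limits leave unreadable from compound 1 to compound 3 is unreadable because compound 3 sits at the limit of > 7400 nM in this assay, at which 1 of the 3 values shown sits. Compound 4 `CCc1nc(-c2cnc3ccc(-c4ccccc4)cc3c2)no1` is not yet measured; it differs from compound 3 by hydrogen in place of methyl on an aromatic carbon, the same change as from compound 1 to compound 2, where no size could be read. A step that the limit leaves unreadable from compound 3 to compound 4 is expected. Compound 4 is expected to give 30000 nM, most likely again only as a limit.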

Compound 4, half-maximal cytotoxic concentration: > 7400 nM
Compound 4 ended at the assay's limit; the forecaster's own chance of this, stated with the estimate: 85%; the middle value is on the limit's open side.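

In this assay the steps linking compound 4 to compound 3 and to compound 2 cannot be read, as all these values are limits. The compounds shown leave open whether either change alters toxicity in this test at all.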